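This account rests on a few compounds, and the source may have more. Where it says the series, first, only, none or still open, it means among the compounds named here.

Working notes on the series. Compound 3 `Clc1ccc(Cl)c(COC(CCn2cncn2)c2ccco2)c1` gives 28900 nM in an ADME assay on J774.A1 cells (Mus musculus) for cytotoxicity, read by MTT assay, with a stated time of 72 h; a lower number here means that less compound is tolerated, a higher number that more compound is tolerated. Compound 1 `Clc1ccc(Cl)c(COC(CCn2ccnc2)c2ccco2)c1` gives 37600 nM in this assay. The change between them is 1H-imidazol-1-yl in place of 1H-1,2,4-triazol-1-yl on a saturated chain carbon, three bonds along the chain from an aromatic carbon and an oxygen on a saturated carbon, and it made a step of a 1.3-fold higher number from compound 3 to compound 1 (0.11 log units; within the scatter). Compound 2 `Fc1ccc(COC(CCn2cncn2)c2cccs2)c(F)c1` gives "not determined" (no result reported) in this assay, so no single number stands for it; the difference between the core of compound 2 and the core of compound 3 is not broken down here. Compound 4 `Fc1ccc(COC(CCn2ccnc2)c2cccs2)c(F)c1` is not yet measured. It differs from compound 2 by 1H-imidazol-1-yl in place of 1H-1,2,4-triazol-1-yl on a saturated chain carbon, three bonds along the chain from an aromatic carbon and an oxygen on a saturated carbon, the same change as from compound 3 to compound 1. A step of similar size is expected from compound 2 to compound 4 in this assay, resting only on the step of a 1.3-fold higher number from compound 3 to compound 1 (0.11 log units; within the scatter), with no value for compound 2 to anchor it. Compound 4 is expected near 35000 nM, in a range from 12000 nM to 100000 nM.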

Compound 4, half-maximal cytotoxic concentration: 34400 nM
Compound 4: middle estimate off by 1.0-fold (0.01 log units), on the high side; the range from low to high includes it.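

Among these compounds, no step from compound 2 to compound 4 can be read, as compound 2 has no single number in this assay. The compounds shown leave open whether 1H-imidazol-1-yl in place of 1H-1,2,4-triazol-1-yl shifts the number on the core of compound 2. Nothing shown bears on a cause.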